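The compounds below may be only part of what the source reports. "The series", "measured", "known", "first", "only" and "open" are said of these compounds alone.

Measured so far:
- compound 1, `ClCc1cccc(Cn2cnc3ncnc(Cl)c32)c1`, in a functional assay on HCT-116 cells (Homo sapiens) for cytotoxicity, read by sulforhodamine B assay, with a stated time of 48 h (on this read-out lower numbers stand for higher toxicity in this test and higher numbers for lower toxicity in this test), gives 9540 nM
- compound 2, `ClCc1cccc(Cn2cnc3c(Cl)ncnc32)c1`, in this assay gives 6310 nM

Among the measured compounds shown here, compound 1 and compound 2 are the only two compounds for which numbers are known. Compound 2 has the lower of the two numbers, and its nearest neighbour is compound 1, whose number is higher, but this gap lies within the scatter of repeated measurements, so the two compounds cannot be separated on what has been measured.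

Compound 3, `ClCc1cccc(Cn2cnc3c(Cl)nc(Cl)nc32)c1`, has not yet been tested. It differs from compound 2 in one place: chloro in place of hydrogen on an aromatic carbon. The new chloro sits on the six-membered aromatic ring of the shared core, between two ring nitrogen atoms, meta to the chloro already present and meta and para to the fused ring.

For the measured compounds named here, no pair of measured compounds differs in just this way, so there is no measured step to lean on. Compound 3 is expected to keep a number close to that of compound 2, with the step of a 1.3-fold lower number from compound 2 to compound 3 (0.10 log units; within the scatter) estimated as small and most likely not beyond the scatter. The estimate for compound 3 is therefore 5000 nM, with a range from 1500 nM to 15000 nM.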

Compound 3, concentration lethal to 50% of the cells: 5880 nM
The estimate for compound 3 lay 1.2-fold (0.07 log units) below the measured number; measured number inside the range.
By their numbers in this assay, from the lowest: compounds 3, 2 and 1 (each within the scatter of the next).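

In this assay, among the compounds shown here, chloro in place of hydrogen on an aromatic carbon of the shared core, between two ring nitrogen atoms, gives a 1.1-fold lower number from compound 2 to compound 3 (0.03 log units; within the scatter) and is the first measured change at this position. It shows that this position can carry a chloro group, one added heavy atom with no ring and no net charge, without a shift that can be told apart from repeat measurement on this read-out. The compounds shown offer no independent measurement that could explain this result.

Chloro is the only replacement for hydrogen seen at this position, so it remains open whether an amine, a methoxy group or a longer chain placed there would move the number in this assay beyond the scatter. Going by these compounds, it also remains open whether chloro at this position would behave the same way on the core of compound 1, where the existing chloro sits elsewhere, and whether any such change would carry over to cell lines other than the one used here.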